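Imide nitrogen alkylation in a GIP receptor agonist series

The source may hold more compounds than are shown below. What is called first, only, known or untested is meant among the compounds shown, and "the series" means these compounds.

Measured compounds:
compound 1, `O=C1c2cc(C3CC3)nc(Oc3cccc(NS(=O)(=O)c4ccc(Cl)cc4)c3)c2C(=O)N1C1CC1`, 45 nM
compound 2, `Cc1cc2c(c(Oc3cccc(NS(=O)(=O)c4ccc(Cl)cc4)c3)n1)C(=O)NC2=O`, 121 nM

Both compounds were tested in a functional assay on HEK293 cells for agonist activity at Glucose-dependent insulinotropic receptor (Homo sapiens), read by cAMP accumulation, with a stated time of 30 min; on this read-out lower numbers stand for an effect already at smaller amounts and higher numbers for an effect only at larger amounts of compound. Compound 1 gives 45 nM. Compound 2 gives 121 nM, the higher of the two numbers, and the gap between them lies beyond the usual scatter. Compound 1 and compound 2 differ in more than one place, so no single change can be read from this pair; the two values only show that the substitution pattern of compound 1 goes with the lower number.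

Compound 3, `CCN1C(=O)c2cc(C)nc(Oc3cccc(NS(=O)(=O)c4ccc(Cl)cc4)c3)c2C1=O`, is not yet measured. Relative to compound 2 the change is ethyl in place of hydrogen on an amide-type nitrogen in a ring. Among the compounds with values here, the only measured compound carrying a substituent on that nitrogen is compound 1, which also differs elsewhere, so the size of this step is not fixed by the data. The step from compound 2 to compound 3 is expected to be small, toward lower numbers, and may stay within the scatter: a 1.6-fold lower number from compound 2 to compound 3 (0.21 log units; within the scatter). Compound 3 is estimated at 75 nM, with a range from 25 nM to 220 nM.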

Compound 3, half-maximal effective concentration: 11 nM
Compound 3: middle estimate off by 6.8-fold (0.83 log units), on the high side, and the stated range ends above it.
By their numbers in this assay, from the lowest: compound 3; then compound 1; then compound 2.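

Ethyl in place of hydrogen on an amide-type nitrogen in a ring gives, in this assay, an 11-fold lower number from compound 2 to compound 3 (1.04 log units; beyond the scatter) and is the first step in this series that isolates this nitrogen. The earlier pair differed in more than one place and could not separate the substituent on this nitrogen from the other changes, whereas this step shows that the nitrogen alone can move the value well beyond the usual scatter. In this pair, the amide hydrogen is not needed for a low number, and ethyl on this nitrogen is accommodated with a clear gain on this read-out; no supporting measurement accounts for the size of the step.

The compounds shown leave open whether the gain continues, levels off or reverses with a longer chain such as propyl or butyl, or with a chain ending in a hydroxyl group or an amine. They also leave open whether a step of this size holds on other versions of the shared core, since this single pair fixes it only on the core of compound 2.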